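The compounds below may be only part of what the source reports. "The series", "measured", "known", "first", "only" and "open" are said of these compounds alone.

Series notes. Compound 1 `COC(=O)c1c(C(=O)c2c(O)cc(C)cc2OC)c(OC)cc(O)c1[S@@+](C)[O-]` does not reach a measurable number in a functional assay, with a stated time of 30 min; a higher number here means a weaker inhibitor, a lower number a stronger inhibitor: in this assay compound 1 gives > 100000 nM, which is a limit. Compound 2 `COC(=O)c1c2c(cc(OC)c1C(=O)c1c(O)cc(C)cc1OC)OC(OC)CS2` also returns a limit, giving > 100000 nM in this assay. Going by the values given here, compound 3 `COc1cc(O)cc(C(=O)O)c1C(=O)c1c(O)cc(C)cc1O` is the single member with a measured number, giving 18900 nM in this assay. Among the compounds with values here, compound 1 therefore stands at the limit together with compound 2 (the limit of > 100000 nM in this assay, at which 2 of the 3 values shown sit), with compound 3 the one value below it. Within the data shown here, no pair of measured compounds differs in a single place, so no measured step sets the scale of one change.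

Compound 4 `COC(=O)c1cc(O)cc(OC)c1C(=O)c1c(O)cc(C)cc1OC` is not yet measured. It differs from compound 1 in one place: a hydrogen atom in place of a group of 3 heavy atoms (1 carbon, 1 oxygen, 1 sulfur; no ring), on an aromatic carbon. Since compound 1 sits at a limit, the step can only be gauged loosely. Compound 3 shows that a measurable number is attainable in this assay with its value of 18900 nM. The step is expected to run downward, estimated as an at least 2.0-fold lower number from compound 1 to compound 4 (0.30 log units; that floor lies within the scatter), possibly no further than the scatter. Compound 4 is expected at 50000 nM, within a range from 10000 nM to 300000 nM, with a real chance that only a limit is reported again.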

Compound 4, half-maximal inhibitory concentration: > 100000 nM
Compound 4 ended at the assay's limit; the forecaster's own chance of this, stated with the estimate: 40%; middle value at least 2.0-fold (0.30 log units) away from the limit.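

Compound 1 and compound 4 both stand at the same limit, so no step between them can be read: the limit of > 100000 nM in this assay, at which 3 of the 4 values shown sit.

The compounds shown leave open which single change separates compound 3, the one measured number, from that limit.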